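Aryl for benzyl: estimating a dichlorophenyl analogue

The compounds below may be only part of what the source reports. "The series", "measured", "known", "first", "only" and "open" are said of these compounds alone.

Compound 1 `c1ccc(OCc2noc(-c3ccc(C4=NCCN4)cc3)n2)cc1`: > 100000 nM
Compound 2 `Cc1ccc(Cc2noc(-c3ccc(C4=NCCN4)cc3)n2)cc1`: 55500 nM

For the measured compounds named here, in an assay for inhibition of Amine oxidase [flavin-containing] A (Homo sapiens), read by fluorescence and spectrophotometry, using microsomes, with stated times of 30 min and 20 min (on this read-out lower numbers stand for stronger inhibition and higher numbers for weaker inhibition), compound 2 gives 55500 nM, the only real number among the two measured compounds. For compound 1 the value > 100000 nM is a limit of the assay, not a number (the limit of > 100000 nM in this assay, at which 1 of the 2 values shown sits). Going by the values given here, the single measured step, an at least 1.8-fold lower number from compound 1 to compound 2 (0.25 log units; that floor lies within the scatter), therefore sets only a floor that the scatter could absorb, so it does not show whether changing the group on the five-membered ring moves the read-out at all.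

Compound 3 `Clc1ccc(-c2noc(-c3ccc(C4=NCCN4)cc3)n2)cc1Cl` differs from compound 2 in one place: 3,4-dichlorophenyl in place of 4-methylbenzyl on an aromatic carbon. Among the compounds with values here, no measured step makes this kind of change, so the expectation rests on compound 2 alone, with a wide range. Compound 3 is expected to give 30000 nM, between 5000 nM and 150000 nM. The expected step of a 1.9-fold lower number from compound 2 to compound 3 (0.27 log units; within the scatter) is small enough that it may lie within the scatter.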

Compound 3, half-maximal inhibitory concentration: 1110 nM
The estimate for compound 3 lay 27-fold (1.43 log units) above the measured number; measured number below the stated range.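

Swapping the group on this carbon of the five-membered ring clearly moves the read-out in this assay, which the earlier pair could not show: replacing 4-methylbenzyl with 3,4-dichlorophenyl gives a 50-fold lower number from compound 2 to compound 3 (1.70 log units; beyond the scatter). Replacing phenoxymethyl with 3,4-dichlorophenyl gives an at least 90-fold lower number from compound 1 to compound 3 (1.95 log units; beyond the scatter). That second step is only a floor, as the value of compound 1 is a limit of the assay and not a number: the limit of > 100000 nM in this assay, at which 1 of the 3 values shown sits.

The step to compound 3 removes the saturated chain carbon and also exchanges the methyl group for two chlorine atoms, so the compounds shown do not reveal which of these changes counts. As far as these compounds go, an unsubstituted phenyl or a 3,4-dichlorobenzyl group on this carbon would separate the two, and how an amine or a carboxylic acid on the aromatic ring would fare remains open.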